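Ester in place of ethoxymethyl on the ring alkene

The source may report more compounds than this note shows. Statements on the series, on what has been measured and on what is new or still open speak of the compounds shown alone.

compound 1 `COc1ccc2c(c1)OC(c1cc(OC)c(OC)c(OC)c1)C(C(=O)N1CCCCC1)=C2`: > 50000 nM
compound 2 `CCOCC1=Cc2ccc(OC)cc2OC1c1cc(OC)c(OC)c(OC)c1`: 21300 nM

Going by the values given here, compound 2 gives the only number in a functional assay for inhibition of nuclear factor NF-kappa-B complex (Homo sapiens); on this read-out lower numbers stand for stronger inhibition and higher numbers for weaker inhibition. Compound 1 shows a limit of the assay in this assay, > 50000 nM, recorded as the limit of > 50000 nM in this assay, at which 1 of the 2 values shown sits. Among the compounds with values here, the single measured step, an at least 2.3-fold lower number from compound 1 to compound 2 (0.37 log units; beyond the scatter), is beyond the scatter, the carbonyl-bearing group giving the weaker result. Compound 3 `COC(=O)C1=Cc2ccc(OC)cc2OC1c1cc(OC)c(OC)c(OC)c1` carries methoxycarbonyl in place of ethoxymethyl on a double-bonded ring carbon; the entering group is again carbonyl-bearing, with one double bond outside aromatic rings and two hydrogen-bond acceptors against one in the leaving group. Within the data shown here, only that step bears on the change, suggesting a modest shift toward weaker inhibition or none beyond the scatter. Compound 3 is expected at 32000 nM, between 10000 nM and 100000 nM, an estimated 1.5-fold higher number from compound 2 to compound 3 (0.18 log units; within the scatter).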

Compound 3, half-maximal inhibitory concentration: 13800 nM
The estimate for compound 3 lay 2.3-fold (0.37 log units) above the measured number; the measured number falls inside the stated range.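

A carbonyl on the double-bonded ring carbon does not by itself go with the weaker result: in this assay there is a 1.5-fold lower number from compound 2 to compound 3 (0.19 log units; within the scatter), so methoxycarbonyl and ethoxymethyl are not told apart. The change on the carbonyl carbon does separate, with an at least 3.6-fold lower number from compound 1 to compound 3 (0.55 log units; beyond the scatter). Compound 1 stands at a limit of the assay, not at a number, so the size of that step stays open: the limit of > 50000 nM in this assay, at which 1 of the 3 values shown sits.

Open, as far as these compounds go, is whether a carboxylic acid or a longer ester chain at this carbon would differ from compound 3. Also open, from the compounds shown here alone, is whether a primary amide would track compound 1 or compound 3.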